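Closing a Branched Amine into a Ring: Compound 3

The source may hold more compounds than are shown below. What is called first, only, known or untested is meant among the compounds shown, and "the series" means these compounds.

Of the compounds shown here, two have been tested in a functional assay on the whole organism for inhibition, with Rattus norvegicus as the target, at a dose of 25 mg/kg by the intraperitoneal route; a lower number here means less inhibition, a higher number more inhibition at the dose given (going by the name of the read-out). Compound 1 `CCCCCn1cnc2c(N(C)C)ncnc21` gives 0%, and compound 2 `CC(C)N(C)c1ncnc2c1ncn2CC1CC1` gives 32%. Compound 2 therefore stands highest of the two numbers, and its nearest neighbour, compound 1, lies lower by an amount beyond the usual scatter. The two measured compounds differ in more than one place, so no single structural change can be read off from them.

Compound 3 `c1nc(N2CCCCC2)c2ncn(CC3CC3)c2n1` differs from compound 2 in one place: piperidin-1-yl in place of isopropyl(methyl)amino on an aromatic carbon. The group that leaves is an open branch; the group that enters is a six-membered non-aromatic ring with one hetero atom. Within the data shown here, with no comparable step measured, the size of the move in this assay cannot be read from the data; a modest change in either direction, or none beyond the scatter, is expected. Compound 3 is expected to give 35%, between 10% and 60%, which means an expected step of a number 3 percentage points higher from compound 2 to compound 3 (within the scatter).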

Compound 3, a percentage reported as inhibition, in the whole organism at one dose (the size of the read-out at that dose, not a potency): 28%
For compound 3 the middle estimate is 7 percentage points above the measured one; low and high end bracket the measured number.
By their numbers in this assay, from the lowest: compound 1; then compounds 3 and 2 (each within the scatter of the next).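

Among these compounds, replacing the open isopropyl(methyl)amino branch with piperidin-1-yl gives the first single change that can be read in this assay, and the outcome is a number 4 percentage points lower from compound 2 to compound 3 (within the scatter). At this aromatic carbon, then, tying the branch into a six-membered non-aromatic ring does not separate the two compounds in this read-out, and the inhibition seen with the open branch is kept with the ring. No available measurement explains why the two groups score alike.

One ring and one branch say little about the range of groups this carbon accepts, so a smaller pyrrolidin-1-yl ring, a morpholin-4-yl ring with its added oxygen, or a simple primary amine could still shift the result in either direction. Going by these compounds, whether any such group would move the inhibition beyond the scatter remains open.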